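The source may report more compounds than this note shows. Statements on the series, on what has been measured and on what is new or still open speak of the compounds shown alone.

Compound 1 `CCCCNc1nc(N)nc(C)c1CCCN(CC)CC` gives 254 nM in an assay on HEK293 cells for agonist activity at Toll-like receptor 8 (Homo sapiens), read by spectrophotometry; a higher number here means that more compound is needed for the effect, a lower number that less compound is needed. Within the data shown here, compound 2 `CCCCNc1nc(N)nc(C)c1CCCN1CCCC1` gives 110 nM, and the single step seen so far, a 2.3-fold lower number from compound 1 to compound 2 (0.36 log units; beyond the scatter), shows the ring amine in place of the open amine at the chain end. On the numbers shown, compound 2 stands lowest of the two, with compound 1 the only neighbour.

Compound 3 `CCCCNc1nc(N)nc(C)c1C` is the next to be measured. It differs from compound 2 by hydrogen in place of 2-(pyrrolidin-1-yl)ethyl on a saturated chain carbon bound to an aromatic carbon. Among the measured compounds shown here, the only measured step concerns the amine at the far end of that same chain, so it touches the part that now leaves, but it does not show what happens when the whole group is gone. For the measured compounds named here, with no direct precedent, he expects a clearly higher number from compound 2 to compound 3, a 27-fold higher number from compound 2 to compound 3 (1.44 log units; beyond the scatter), and estimates compound 3 at 3000 nM, within 500 nM to 20000 nM.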

Compound 3, half-maximal effective concentration: 3280 nM
The estimate for compound 3 lay 1.1-fold (0.04 log units) below the measured number, within the range that was stated.
By their numbers in this assay, from the lowest: compound 2; then compound 1; then compound 3.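

In this assay, hydrogen in place of the whole 2-(pyrrolidin-1-yl)ethyl group on a saturated chain carbon bound to an aromatic carbon gives a 30-fold higher number from compound 2 to compound 3 (1.47 log units; beyond the scatter), a far larger move than the earlier exchange of one amine for the other. The same change from the 2-(diethylamino)ethyl group gives a 13-fold higher number from compound 1 to compound 3 (1.11 log units; beyond the scatter), so the number rises with both amines when the group leaves, and its presence counts for more here than which of the two amines it carries. Nothing measured here explains this rise. The compounds shown leave open whether the chain or its amine accounts for the difference, as the two leave together. A longer chain, a shorter chain ending in pyrrolidine, or a chain ending in a hydroxyl group would bear on that question.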